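Aryl ether swap on the shared core: expected tolerance

A few compounds are considered here, and "the series" means these few. Any claim that something is new, unique, unknown or untested is made for them only; others in the source may bear on it.

Compound 1 `COc1cc(C#N)ccc1Oc1nc(Nc2ccc(C#N)cc2)nc2ccccc12` in an ADME assay on MT4 cells (Homo sapiens) for cytotoxicity, read by MTT assay, with a stated time of 4 days (a lower number here means that less compound is tolerated, a higher number that more compound is tolerated), gives >= 140000 nM, which is a limit of the assay rather than a number (the limit of >= 140000 nM in this assay, at which 1 of the 2 values shown sits). Compound 2 `COc1cc(C#N)cc(Cl)c1Oc1nc(Nc2ccc(C#N)cc2)nc2ccccc12` in this assay gives 220000 nM. The step that the limit leaves unreadable from compound 1 to compound 2 is therefore of unreadable size. Compound 3 `N#Cc1ccc(Nc2nc(Oc3c(Br)cc(Br)cc3Br)c3ccccc3n2)cc1` differs from compound 1 by 2,4,6-tribromophenyl in place of 4-cyano-2-methoxyphenyl on an oxygen on an aromatic ring. Within the data shown here, no measured step covers this change, and the one step known is unreadable, so no direction can be drawn from the series. For compound 3 the expected value in this assay is 100000 nM, within 30000 nM to 300000 nM. The expected step of an at least 1.4-fold lower number from compound 1 to compound 3 (0.14 log units; that floor lies within the scatter) thus stays near the scatter, with a limit again a real possibility.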

Compound 3, half-maximal cytotoxic concentration: 58000 nM
Compound 3: the middle estimate sits 1.7-fold (0.24 log units) above what was measured, within the range that was stated.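

In this assay, among these compounds, the aryl group on an oxygen on an aromatic ring gives the first readable step: 2,4,6-tribromophenyl in place of 4-cyano-2-methoxyphenyl gives an at least 2.4-fold lower number from compound 1 to compound 3 (0.38 log units; beyond the scatter). The change therefore moves the series towards less tolerated compound. Compound 1 stands at a limit of the assay, so the step is a floor only: the limit of >= 140000 nM in this assay, at which 1 of the 3 values shown sits.

Open, as far as these compounds go, is which part of the swap carries the step, the bromines or the loss of the nitrile and methoxy. Also open, from the compounds shown here alone, is how an aryl ring bearing an amine or a carboxylic acid would behave here.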